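Replacing the aryl chloro of compound 3 with dimethylamino

The source may report more compounds than this note shows. Statements on the series, on what has been measured and on what is new or still open speak of the compounds shown alone.

Within the data shown here, compound 3 `O=C1N=C(N2N=C(c3ccccc3)CC2c2ccc(Cl)cc2)S/C1=C1/C(=O)Nc2ccccc21` gives 70800 nM in a functional assay on cells (Leukemia cell, Homo sapiens) for cytotoxicity, read by sulforhodamine B assay, with a stated time of 48 h (on this read-out lower numbers stand for stronger inhibition of growth and higher numbers for weaker inhibition of growth), the highest of the three numbers measured so far. Compound 1 `O=C1N=C(N2N=C(c3ccccc3)CC2c2ccccc2O)S/C1=C1/C(=O)Nc2ccccc21` gives 48800 nM and compound 2 `COc1ccc(C2CC(c3ccccc3)=NN2C2=NC(=O)/C(=C3\C(=O)Nc4ccccc43)S2)cc1` gives 20800 nM; the step of a 1.5-fold higher number from compound 1 to compound 3 (0.16 log units; within the scatter) lies within the scatter, whereas a 2.3-fold lower number from compound 1 to compound 2 (0.37 log units; beyond the scatter) and a 3.4-fold higher number from compound 2 to compound 3 (0.53 log units; beyond the scatter) lie beyond it. Compound 4 `CN(C)c1ccc(C2CC(c3ccccc3)=NN2C2=NC(=O)/C(=C3\C(=O)Nc4ccccc43)S2)cc1` carries dimethylamino in place of chloro on an aromatic carbon, para to a large group. Among the measured compounds shown here, the only measured guide at this position is the methoxy-to-chloro step, a 3.4-fold higher number from compound 2 to compound 3 (0.53 log units; beyond the scatter); the change to compound 4 again exchanges the substituent at that place, and the closest precedent points toward a modest lowering rather than no change. Compound 4 is therefore expected to step a 3.2-fold lower number from compound 3 to compound 4 (0.51 log units; beyond the scatter). Compound 4 is estimated at 22000 nM, with a range of 8000 nM to 60000 nM.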

Compound 4, concentration for total growth inhibition: 45600 nM
Estimate against measurement, compound 4: 2.1-fold (0.32 log units) below, within the range that was stated.
By their numbers in this assay, from the lowest: compound 2; then compounds 4, 1 and 3 (each within the scatter of the next).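

In this assay the exchange of chloro for dimethylamino gives no readable change: a 1.6-fold lower number from compound 3 to compound 4 (0.19 log units; within the scatter) stands within the scatter, as does a 1.1-fold lower number from compound 1 to compound 4 (0.03 log units; within the scatter) for the exchange of the whole aryl group. Dimethylamino does not match methoxy at this place, with a 2.2-fold higher number from compound 2 to compound 4 (0.34 log units; beyond the scatter) beyond the scatter, so compound 2 alone now stands apart from all the others. Nothing at hand accounts for that gap between methoxy and dimethylamino.

On these data alone, whether the lower number of compound 2 is particular to methoxy stays open. Ethoxy, hydroxy or a primary amine at this place on the shared core would test that.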